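Adding a Nonyl Chain to Compound 3

The source may hold more compounds than are shown below. What is called first, only, known or untested is meant among the compounds shown, and "the series" means these compounds.

In a functional assay on T47D cells (Homo sapiens) for cytotoxicity, read by MTT assay, with a stated time of 48 h (on this read-out higher numbers stand for weaker inhibition and lower numbers for stronger inhibition), compound 3 (`C[n+]1cccc(OP(=O)([O-])OC[C@H]2O[C@@H](n3cc(F)c(=O)[nH]c3=O)C[C@@H]2OC(=O)c2ccccc2)c1`) gives 3910 nM. Compound 2 (`O=C(O[C@H]1C[C@H](n2cc(F)c(=O)[nH]c2=O)O[C@@H]1COP(=O)(O)Oc1ccc2ncccc2c1)c1ccccc1`) gives 7140 nM, within the scatter of compound 3, while compound 1 (`CCCCCCCCCc1ccc(OP(=O)(O)OC[C@H]2O[C@@H](n3cc(F)c(=O)[nH]c3=O)C[C@@H]2OC(=O)c2ccccc2)cc1`) gives 26700 nM, a number beyond the scatter on the weaker side. Compound 4 (`CCCCCCCCCC[n+]1cccc(OP(=O)([O-])OC[C@H]2O[C@@H](n3cc(F)c(=O)[nH]c3=O)C[C@@H]2OC(=O)c2ccccc2)c1`) has nonyl in place of hydrogen on a saturated chain carbon bound to an aromatic nitrogen, so methyl becomes decyl. For the measured compounds named here, no measured pair differs in one place, which leaves the step a matter of judgement. Compound 1 also carries a nonyl chain, and its 26700 nM gives no promise of a large gain. Only a small move toward stronger inhibition is expected, estimated as a 1.6-fold lower number from compound 3 to compound 4 (0.19 log units; within the scatter). The estimate for compound 4 is 2500 nM, with an expected range of 500 nM to 12000 nM.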

Compound 4, half-maximal inhibitory concentration: 8730 nM
Beside the measured number, compound 4's estimate is 3.5-fold (0.54 log units) below it; measured number inside the range.
By their numbers in this assay, from the lowest: compounds 3, 2 and 4 (each within the scatter of the next, the first and the last beyond it); then compound 1.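

For the compounds shown here, the change from methyl to decyl, on a saturated chain carbon bound to an aromatic nitrogen, is the first single change that can be read here. In this assay it gives a 2.2-fold higher number from compound 3 to compound 4 (0.35 log units; beyond the scatter) and so weakens inhibition modestly, which means the added nonyl brings no gain at this place. No measurement shown accounts for this loss.

Going by these compounds, it remains open whether a shorter chain such as butyl would keep the number of compound 3 . A decyl chain ending in an amine or a carboxylic acid is also untested among the compounds shown.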